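Isopropyl for Methyl on the Ring Nitrogen: Expected Half-Life

This account rests on a few compounds, and the source may have more. Where it says the series, first, only, none or still open, it means among the compounds named here.

Compound 1, `CC(C)N1CC(=O)N=C1N/C(=N\C(=O)C(C)(C)C)Nc1ccc(Cl)c(Cl)c1`, gives > 1 h in an in vivo ADME assay on the whole organism for metabolic stability, with Homo sapiens as the target, read by LC-MS, at a dose of 160 mg/kg by the oral route; on this read-out lower numbers stand for a shorter-lived compound and higher numbers for a longer-lived compound.
Compound 2, `CC(C)(C)N1CC(=O)N=C1NC(=N)Nc1ccc(Cl)c(Cl)c1`, gives > 1 h in this assay.
Compound 3, `CN1CC(=O)N=C1N/C(=N\C(=O)OC(C)(C)C)Nc1ccc(Cl)c(Cl)c1`, gives < 0.167 h in this assay.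

None of these three readings is a number. Compound 3 sits at the limit of < 0.167 h in this assay, at which 1 of the 3 values shown sits, so its half-life is known only as a limit. Compound 1 sits at the limit of > 1 h in this assay, at which 2 of the 3 values shown sit, again only a limit. Compound 2 sits at that same upper limit, also only a limit. Among the measured compounds shown here, no two of the measured compounds differ in a single place, so no measured step can be drawn between them; what can be said is that compound 3 stands at the short end of what this assay reports, while compound 1 and compound 2 stand at the long end.

Compound 4, `CC(C)N1CC(=O)N=C1N/C(=N\C(=O)OC(C)(C)C)Nc1ccc(Cl)c(Cl)c1`, has not yet been measured in this assay. It differs from compound 3 in one place: isopropyl in place of methyl on an amine nitrogen in a ring.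

Because compound 1, which carries an isopropyl at that ring nitrogen, gives > 1 h, the expectation for compound 4 is a move toward longer half-life, of a size an at least 2.9-fold higher number from compound 3 to compound 4 (0.47 log units; beyond the scatter) that goes beyond the usual scatter. Compound 4 is therefore estimated at 0.5 h, within a range from 0.12 h to 2 h.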

Compound 4, half-life: 0.213 h
Compound 4: middle estimate off by 2.3-fold (0.37 log units), on the high side, within the range that was stated.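

With isopropyl in place of methyl on an amine nitrogen in a ring, this assay gives an at least 1.2-fold higher number from compound 3 to compound 4 (0.10 log units; that floor lies within the scatter), so the compounds shown do not establish that this change alone lengthens half-life beyond the usual scatter. The reading for compound 3 is a limit and not a number, which leaves the true size of this step unknown: the limit of < 0.167 h in this assay, at which 1 of the 4 values shown sits.

Isopropyl at this position also does not by itself place a compound at the long end of the assay, since tert-butoxy in place of tert-butyl on a carbonyl carbon gives an at least 4.6-fold lower number from compound 1 to compound 4 (0.67 log units; beyond the scatter), a step known only as a floor but one that lies beyond the scatter.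

The compounds shown leave open whether an ethyl group or a longer chain on the same ring nitrogen would move half-life clearly away from the methyl compound. They also leave open whether isopropyl in place of methyl would give a larger step with tert-butyl, rather than tert-butoxy, on the carbonyl carbon.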